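Swapping Nitro for Methyl at the Assay Ceiling

The source may hold more compounds than are shown below. What is called first, only, known or untested is meant among the compounds shown, and "the series" means these compounds.

Three compounds share one core and differ only in the group on the outer benzyl ring. In an ADME assay on Vero cells (Chlorocebus sabaeus) for cytotoxicity, with a stated time of 72 h (a lower number here means a stronger inhibitor, a higher number a weaker inhibitor), compound 1 `CCOC(=O)c1cc(-c2cccc(OCc3cccc(C(F)(F)F)c3)c2)on1` gives > 128000 nM, which is a limit of the assay rather than a number. Compound 2 `CCOC(=O)c1cc(-c2cccc(OCc3cccc(Br)c3)c2)on1` in this assay gives > 128000 nM, again a limit. Compound 3 `CCOC(=O)c1cc(-c2cccc(OCc3cccc([N+](=O)[O-])c3)c2)on1` in this assay gives > 128000 nM, also a limit. Because all three sit at the limit of > 128000 nM in this assay, at which 3 of the 3 values shown sit, the steps between them cannot be read: a step that the two limits leave unreadable from compound 1 to compound 2, a step that the two limits leave unreadable from compound 1 to compound 3 and a step that the two limits leave unreadable from compound 2 to compound 3. Compound 3 therefore stands where every measured compound stands, at the ceiling, with none shown stronger or weaker than another.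

Compound 4 `CCOC(=O)c1cc(-c2cccc(OCc3cccc(C)c3)c2)on1` differs from compound 3 by methyl in place of nitro on an aromatic carbon. For the measured compounds named here, no measured step has a readable size, so none points in a direction; the only guidance is that each group tried so far has left the value at the limit. Compound 4 is therefore expected to behave likewise, with an expected step that the limit leaves unreadable from compound 3 to compound 4. The estimate for compound 4 in this assay is 250000 nM, between 100000 nM and 1000000 nM, and most likely only a limit will again be reported.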

Compound 4, half-maximal inhibitory concentration: > 128000 nM
Compound 4 ended at the assay's limit; the forecaster's own chance of this, stated with the estimate: 85%; the middle value does not contradict the limit.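

Compound 4 also sits at a limit rather than a number, so its steps to compound 1, compound 2 and compound 3 cannot be read: the limit of > 128000 nM in this assay, at which 4 of the 4 values shown sit.

As far as these compounds go, whether these four compounds truly differ in this assay remains open, as none of them gives an actual number.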